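The compounds below may be only part of what the source reports. "The series", "measured", "known", "first", "only" and "open" are said of these compounds alone.

Of the compounds shown here, three with one shared core have been tested in a functional assay on L1210 cells (Mus musculus) for cytotoxicity, with a stated time of 48 h; on this read-out lower numbers stand for stronger inhibition and higher numbers for weaker inhibition. Compound 1 `O=C1/C(=C/c2ccccc2)CCC/C1=C\c1ccc([N+](=O)[O-])cc1` gives 9800 nM. Among the measured compounds shown here, compound 3 `O=C1/C(=C/c2ccc(F)cc2)CCC/C1=C\c1ccc([N+](=O)[O-])cc1` gives 26800 nM, and this pair forms the only step between measured compounds that differ in a single place: a 2.7-fold higher number from compound 1 to compound 3 (0.44 log units; beyond the scatter). Compound 2 `Cc1ccc(/C=C2\CCC/C(=C\c3cccc([N+](=O)[O-])c3)C2=O)cc1` gives 41800 nM, the highest of the three numbers; its gap to compound 3 lies within the usual scatter, while its gap to compound 1 lies beyond it.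

Compound 4 `O=C1/C(=C/c2ccc(F)cc2)CCC/C1=C\c1cccc([N+](=O)[O-])c1` has not yet been measured. It differs from compound 2 in one place: fluoro in place of methyl on an aromatic carbon. For the measured compounds named here, no measured step swaps methyl for fluoro directly, and nothing here shows how methyl compares with hydrogen, so the only guide is the modest hydrogen-to-fluoro step between compound 1 and compound 3. On that basis the change from compound 2 to compound 4 is expected to be small, with no clear direction, and may well stay within the scatter. Compound 4 is therefore expected to give about 40000 nM in this assay, within a range from 15000 nM to 110000 nM. That amounts to an expected 1.0-fold lower number from compound 2 to compound 4 (0.02 log units; within the scatter).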

Compound 4, half-maximal inhibitory concentration: 16300 nM
For compound 4 the middle estimate is 2.5-fold (0.39 log units) above the measured one; low and high end bracket the measured number.
By their numbers in this assay, from the lowest: compounds 1, 4, 3 and 2 (each within the scatter of the next, the first and the last beyond it).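

Exchanging 4-methylphenyl for 4-fluorophenyl gives a 2.6-fold lower number from compound 2 to compound 4 (0.41 log units; beyond the scatter) in this assay and lies beyond the scatter, so this aromatic carbon, para to a large group, responds to what it carries, even though methyl and fluoro each count as a single heavy atom. Fluoro now appears in two one-place changes with opposite outcomes: replacing hydrogen gave a 2.7-fold higher number from compound 1 to compound 3 (0.44 log units; beyond the scatter) while replacing methyl gave a lower number, so the entering fluoro alone does not set the direction, although the two pairs also differ in the placing of the nitro group. No available measurement explains this difference.

The compounds shown leave open how a plain hydrogen at this place compares with methyl and fluoro when the nitro group is placed as in compound 2 and compound 4, so it cannot yet be said whether methyl raises the number or fluoro lowers it. They also leave open how a chloro, methoxy or amino group would behave at this same carbon, and whether any such group would bring the number down further.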